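Tail flick series: valine ester to glutamate diester

The compounds below may be only part of what the source reports. "The series", "measured", "known", "first", "only" and "open" are said of these compounds alone.

Measured so far:
compound 1 `CC(C)[C@H](NC(=O)CN(c1ncnc2c1ncn2C1CCCCO1)C1CC1)C(=O)OCc1ccccc1` gives 34.9% in a functional assay on the whole organism (Tail, strain ICR) with Mus musculus as the target, in the tail flick test, with a stated time of 60 min, at a dose of 25 umol/kg by the oral route; on this read-out lower numbers stand for a weaker effect and higher numbers for a stronger effect at the one dose given
compound 2 `CC(C)[C@H](NC(=O)CN(c1nc(Cl)nc2[nH]cnc12)C1CC1)C(=O)O` gives 38.8% in this assay

Compound 1 and compound 2 lie within the scatter of each other, so neither can be set above the other. Compound 3 `O=C(CN(c1ncnc2c1ncn2C1CCCCO1)C1CC1)N[C@@H](CCC(=O)OCc1ccccc1)C(=O)OCc1ccccc1` is not yet measured in this assay. It differs from compound 1 by 2-(benzyloxycarbonyl)ethyl in place of isopropyl on a saturated chain carbon bound to an amide-type nitrogen and a carbonyl carbon. Going by the values given here, no measured pair shows what such a change does here, so the expected step is none beyond the scatter, with a slight lean downward. Compound 3 is estimated at 32%, range 15% to 50%, which means an expected step of a number 2.9 percentage points lower from compound 1 to compound 3 (within the scatter).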

Compound 3, a percentage reported as activity, at one dose (the size of the read-out at that dose, not a potency): 34.7%
The estimate for compound 3 lay 2.7 percentage points below the measured number, within the range that was stated.
By their numbers in this assay, from the lowest: compounds 3, 1 and 2 (each within the scatter of the next).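

In this assay, 2-(benzyloxycarbonyl)ethyl in place of isopropyl on a saturated chain carbon bound to an amide-type nitrogen and a carbonyl carbon gives a number 0.2 percentage points lower from compound 1 to compound 3 (within the scatter). This position therefore takes the larger group, with its six-membered aromatic ring and two hydrogen-bond acceptors, with no step beyond the scatter at this one dose. Nothing available bears on the reason for this result.

Going by these compounds, whether an aminobutyl chain at this place would also stay within the scatter of compound 1 remains open.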